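This account rests on a few compounds, and the source may have more. Where it says the series, first, only, none or still open, it means among the compounds named here.

Compound 2 `COc1cccc(CNCCCNc2ccnc3cc(Oc4ccc(Cl)cc4)ccc23)c1O` is one of three compounds examined in an ADME assay for permeability, using PAMPA, with a stated time of 30 min, at pH 7.4; on this read-out higher numbers stand for higher permeability and lower numbers for lower permeability. Compound 2 gives 317 10^-6 cm/s, level with compound 1 `COc1ccccc1Oc1ccc2c(NCCCNCc3ccco3)ccnc2c1`, which gives 317 10^-6 cm/s; compound 3 `Cc1cc(C)cc(Cc2ccc3c(NCCCNCc4ccco4)ccnc3c2)c1` gives 23 10^-6 cm/s, and the two level compounds stand together at the top. Compound 4 `COc1cccc(CNCCCNc2ccnc3cc(-c4ccc(F)cc4)ccc23)c1O` has not yet been measured. It differs from compound 2 in one place: 4-fluorophenyl in place of 4-chlorophenoxy on an aromatic carbon. Among the measured compounds shown here, the only measured step bears on this only loosely, since it swapped a ring joined through an oxygen for one joined through a carbon chain and gave a 14-fold lower number from compound 1 to compound 3 (1.14 log units; beyond the scatter), a large drop. As that step also removed the oxygen link, a moderate drop is expected here, a 2.1-fold lower number from compound 2 to compound 4 (0.32 log units; beyond the scatter), and compound 4 is estimated at 150 10^-6 cm/s, between 50 10^-6 cm/s and 320 10^-6 cm/s.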

Compound 4, apparent permeability: 237 10^-6 cm/s
The estimate for compound 4 lay 1.6-fold (0.20 log units) below the measured number; low and high end bracket the measured number.
By their numbers in this assay, from the lowest: compound 3; then compounds 4, 1 and 2 (each within the scatter of the next).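

In this assay, placing 4-fluorophenyl instead of 4-chlorophenoxy on this aromatic carbon gives a 1.3-fold lower number from compound 2 to compound 4 (0.13 log units; within the scatter). At this position, then, a ring joined directly to the shared core can stand in for one joined through oxygen with no change beyond the scatter, unlike the ring joined through a carbon chain in a 14-fold lower number from compound 1 to compound 3 (1.14 log units; beyond the scatter). Nothing measured here gives a reason for this result.

The step removes the oxygen link and exchanges chlorine for fluorine together, and these two changes cannot be told apart. A 4-chlorophenyl group at this position would separate them.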